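Removing a Heptyl Chain at Two Different Places

A few compounds are considered here, and "the series" means these few. Any claim that something is new, unique, unknown or untested is made for them only; others in the source may bear on it.

Of the compounds shown here, three have been measured in a functional assay on HCT-116 cells (Homo sapiens) for antiproliferative activity, read by MTT assay, with a stated time of 48 h (on this read-out higher numbers stand for weaker inhibition and lower numbers for stronger inhibition), and a fourth awaits its turn. Compound 1 `CCCCCC(CCO)n1cnc2c(Cl)ncnc21` and compound 3 `CCCCCCCCCCCCC(CCO)n1cnc2c(Cl)ncnc21` share one core and differ only in the length of a chain. In this assay compound 1 gives > 50000 nM, which is a limit of the assay and not a number. In this assay compound 3 likewise gives > 50000 nM, again a limit. The change from compound 3 to compound 1 is hydrogen in place of heptyl on a saturated chain carbon, six bonds along the chain from an aromatic nitrogen, and its step, a step that the two limits leave unreadable from compound 3 to compound 1, cannot be sized because both compounds sit at the limit of > 50000 nM in this assay, at which 2 of the 3 values shown sit.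

Compound 2 `CCCCCCCC(CCO)n1cnc2c(Cl)nc(F)nc21` stands on a different core; the difference between the two cores is not broken down here. In this assay, among the compounds with values here, compound 2 gives 17600 nM, the only plain number among the three. Compound 4 `OCCCn1cnc2c(Cl)nc(F)nc21` differs from compound 2 by hydrogen in place of heptyl on a saturated chain carbon bound to an aromatic nitrogen and a saturated chain carbon. Within the data shown here, this is the same kind of change as the one from compound 3 to compound 1, but not the same: there the chain carbon lies six bonds along the chain from an aromatic nitrogen, here it is bound to an aromatic nitrogen and a saturated chain carbon.

Since the measured step is unreadable, the expectation rests only on compound 2 and its value 17600 nM. The step from compound 2 to compound 4 is expected to be a 3.4-fold higher number from compound 2 to compound 4 (0.53 log units; beyond the scatter), a loss rather than a gain. Compound 4 is estimated at 60000 nM in this assay, somewhere from 15000 nM to 250000 nM, and may well come back only as a limit.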

Compound 4, half-maximal inhibitory concentration: 39800 nM
The estimate for compound 4 lay 1.5-fold (0.18 log units) above the measured number; the range from low to high includes it.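

In this assay, hydrogen in place of heptyl on a saturated chain carbon bound to an aromatic nitrogen and a saturated chain carbon gives a 2.3-fold higher number from compound 2 to compound 4 (0.35 log units; beyond the scatter), a loss of inhibition that lies beyond the usual scatter. The other core offers no measured comparison, since its change from compound 3 to compound 1 also removes a heptyl group, but at a different place, six bonds along the chain from an aromatic nitrogen, and that step cannot be read because both compounds sit at a limit of the assay: the limit of > 50000 nM in this assay, at which 2 of the 4 values shown sit. This single pair therefore shows what the change does on one core and at one place, but it does not show that the same change would have a similar effect on another core, and it does not explain why the number rises.

The compounds shown leave open how inhibition would respond if that same chain carbon carried an amine, a carboxylic acid or a chain of another length instead of heptyl. Also open, on these data alone, is how the two cores compare when both carry one and the same chain.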